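Swapping an amine ring for a methylsulfonyl group on an amide

A few compounds are considered here, and "the series" means these few. Any claim that something is new, unique, unknown or untested is made for them only; others in the source may bear on it.

Three measured compounds share one core. Compound 2 `Cc1cc(C)cc(S(=O)(=O)c2c(C(=O)N[C@@H]3CCNC3)[nH]c3ccc(Cl)cc23)c1` gives 37300 nM in an ADME assay on MT4 cells (Homo sapiens) for cytotoxicity, read by MTT assay, with a stated time of 5 days; a lower number here means that less compound is tolerated, a higher number that more compound is tolerated. Compound 1 `Cc1cc(C)cc(S(=O)(=O)c2c(C(=O)NC3CNC3)[nH]c3ccc(Cl)cc23)c1` gives 37300 nM, and no change at the digits printed from compound 1 to compound 2 (within the scatter). Compound 3 `Cc1cc(C)cc(S(=O)(=O)c2c(C(=O)N[C@H]3CCN(CC(N)=O)C3)[nH]c3ccc(Cl)cc23)c1` gives 28100 nM, and a 1.3-fold lower number from compound 2 to compound 3 (0.12 log units; within the scatter), as does a 1.3-fold lower number from compound 1 to compound 3 (0.12 log units; within the scatter). So compound 2 stands level with compound 1, the two highest of the three numbers, with compound 3 close by.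

Compound 4 `Cc1cc(C)cc(S(=O)(=O)c2c(C(=O)NS(C)(=O)=O)[nH]c3ccc(Cl)cc23)c1` differs from compound 2 in this way: methylsulfonyl in place of pyrrolidin-3-yl on an amide-type nitrogen. Every measured step at this amide-type nitrogen was small, but none replaced the ring with a methylsulfonyl, so the guidance is limited. Compound 4 is therefore expected to show a 1.1-fold lower number from compound 2 to compound 4 (0.03 log units; within the scatter). The estimate for compound 4 is 35000 nM, within 15000 nM to 80000 nM.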

Compound 4, half-maximal cytotoxic concentration: 40200 nM
Compound 4: middle estimate off by 1.1-fold (0.06 log units), on the low side; measured number inside the range.
By their numbers in this assay, from the lowest: compounds 3, 1, 2 and 4 (each within the scatter of the next).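

Earlier steps at this amide-type nitrogen only exchanged one ring-bearing group for another, whereas methylsulfonyl has no ring, and in this assay all three new steps still lie within the scatter (a 1.1-fold higher number from compound 2 to compound 4 (0.03 log units; within the scatter); a 1.1-fold higher number from compound 1 to compound 4 (0.03 log units; within the scatter); a 1.4-fold higher number from compound 3 to compound 4 (0.16 log units; within the scatter)). So, among these four compounds, the ring is not needed to keep this number within the scatter. No measurement shown explains this result. The compounds shown leave open whether a carboxylic acid or a longer alkyl chain on this nitrogen would also stay within the scatter.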